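Benzyl ether variation in the shared core series

The compounds below may be only part of what the source reports. "The series", "measured", "known", "first", "only" and "open" are said of these compounds alone.

Measured so far in a functional assay on U-251 cells (Homo sapiens) for antiproliferative activity, read by MTT assay, with a stated time of 24 h; a higher number here means a weaker inhibitor, a lower number a stronger inhibitor:
compound 1 `COc1cc(OC)c(-c2coc3cc(OCc4ccccc4F)ccc3c2=O)cc1OC` — 2890 nM
compound 2 `COc1cc(OC)c(-c2coc3cc(OCc4ccccc4Br)ccc3c2=O)cc1OC` — > 10000 nM

Compound 1 gives 2890 nM in this assay; it is the only plain number shown. For compound 2 this assay reports a limit only, > 10000 nM. For the measured compounds named here, the single measured step, an at least 3.4-fold higher number from compound 1 to compound 2 (0.53 log units; beyond the scatter), bears on the next compound, since it too alters the benzyl ether; its size is bounded by the limit of > 10000 nM in this assay, at which 1 of the 2 values shown sits.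

Compound 3 `COc1cc(OC)c(-c2coc3cc(OCc4ccc(C(F)(F)F)cc4)ccc3c2=O)cc1OC` differs from compound 1 thus: 4-(trifluoromethyl)phenyl in place of 2-fluorophenyl on a saturated chain carbon bound to an oxygen on an aromatic ring. Bromo in place of fluoro already weakened compound 2 beyond the scatter, and compound 3 replaces the 2-fluorophenyl outright with a differently substituted ring, so a weakening step is expected, roughly a 2.4-fold higher number from compound 1 to compound 3 (0.38 log units; beyond the scatter), with a real chance that only a limit is reported. Compound 3 is therefore estimated at 7000 nM, within 2500 nM to 20000 nM.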

Compound 3, half-maximal inhibitory concentration: 3750 nM
For compound 3 the middle estimate is 1.9-fold (0.27 log units) above the measured one; measured number inside the range.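

In this assay, the benzyl ether accepts a different ring substituent without a resolved shift: 4-(trifluoromethyl)phenyl in place of 2-fluorophenyl gives a 1.3-fold higher number from compound 1 to compound 3 (0.11 log units; within the scatter). The loss seen with bromo therefore does not extend to every change on this ring, and compound 2 is the only one of the three that goes against the otherwise matching readings. The other comparison gives an at least 2.6-fold lower number from compound 2 to compound 3 (0.42 log units; beyond the scatter), and its size is bounded only: the limit of > 10000 nM in this assay, at which 1 of the 3 values shown sits.

Compound 3 alters both the substituent and its place on the ring, so these two changes cannot be separated here; a 4-fluorophenyl or 4-bromophenyl group would part them. On these data alone, how an amine or a carboxylic acid on this ring, or a longer chain on the ether oxygen, would read remains open.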